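A Thiazole in Place of the Fluorophenyl Ring

This account rests on a few compounds, and the source may have more. Where it says the series, first, only, none or still open, it means among the compounds named here.

Of the compounds shown here, two have been tested in a functional assay for agonist activity at G protein-coupled receptor 88 (Homo sapiens), read by HTRF and cAMP accumulation; on this read-out lower numbers stand for an effect already at smaller amounts and higher numbers for an effect only at larger amounts of compound. Compound 1 `N[C@@H](CC1CCCCC1)CN(C(=O)[C@@H]1C[C@H]1c1ccccc1)c1ccc(-c2ccccc2)cc1` gives 1.7 nM in this assay. Compound 2 `CC[C@H](C)[C@H](N)CN(C(=O)[C@@H]1C[C@H]1c1cccc(F)c1)c1ccc(-c2ccccc2)cc1` gives 560 nM in this assay, the higher of the two numbers and far above compound 1. Compound 3 `CC[C@H](C)[C@H](N)CN(C(=O)[C@@H]1C[C@H]1c1csc(C)n1)c1ccc(-c2ccccc2)cc1` has not been measured; it differs from compound 2 by 2-methyl-1,3-thiazol-4-yl in place of 3-fluorophenyl on a saturated ring carbon. Among the compounds with values here, no measured pair shows this exchange, so the direction is uncertain; a modest shift toward higher numbers is expected, as a 2.1-fold higher number from compound 2 to compound 3 (0.33 log units; beyond the scatter). Compound 3 is therefore estimated at 1200 nM in this assay, with a range from 200 nM to 6000 nM.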

Compound 3, half-maximal effective concentration: 1500 nM
Estimate against measurement, compound 3: 1.3-fold (0.10 log units) below, and the stated range covers the measured number.
By their numbers in this assay, from the lowest: compound 1; then compound 2; then compound 3.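

On the saturated ring carbon of the three-membered ring, 2-methyl-1,3-thiazol-4-yl in place of 3-fluorophenyl gives a 2.7-fold higher number from compound 2 to compound 3 (0.43 log units; beyond the scatter) in this assay. This position therefore still gives a measurable effect with a five-membered aromatic ring holding two hetero atoms, but the number moves up rather than down. Nothing available here accounts for this shift.

As far as these compounds go, it remains open whether a pyridin-3-yl group or a thiazole without the methyl group would give a lower number. From the compounds shown here alone, it is also open whether the same exchange would have a similar effect on the core of compound 1.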